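This account rests on a few compounds, and the source may have more. Where it says the series, first, only, none or still open, it means among the compounds named here.

Compound 2 `Cc1cc(C)c(Oc2nc(Nc3ccc(C#N)cc3)nc3ccccc23)c(C)c1` carries a 2,4,6-trimethylphenyl on an oxygen on an aromatic ring. In an ADME assay on MT4 cells (Homo sapiens) for cytotoxicity, read by MTT assay, with a stated time of 4 days (a higher number here means that more compound is tolerated, a lower number that less compound is tolerated), compound 2 gives only a limit, > 34000 nM. Going by the values given here, its one measured neighbour, compound 1 `N#Cc1ccc(Nc2nc(Oc3ccc(F)cc3)c3ccccc3n2)cc1`, carries a 4-fluorophenyl at that same place. In this assay compound 1 likewise gives only a limit, > 351000 nM. Among the compounds with values here, the single step between them, a step that the two limits leave unreadable from compound 1 to compound 2, cannot be read because the limit of > 351000 nM in this assay, at which 1 of the 2 values shown sits, and the limit of > 34000 nM in this assay, at which 1 of the 2 values shown sits, are where its two values sit. Compound 3 `N#Cc1ccc(Nc2nc(Oc3c(Cl)cc(Cl)cc3Cl)c3ccccc3n2)cc1` is reached from compound 2 by the change (2,4,6-trichlorophenyl in place of 2,4,6-trimethylphenyl on an oxygen on an aromatic ring). Within the data shown here, no measured step speaks directly to this exchange, and the one step that exists at this position is unreadable in size and direction. Compound 3 is therefore expected to show no step beyond the scatter in this assay, that is a step that the limit leaves unreadable from compound 2 to compound 3. Compound 3 is accordingly estimated at 50000 nM, within a range from 15000 nM to 200000 nM.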

Compound 3, half-maximal cytotoxic concentration: 56000 nM
For compound 3 the middle estimate is 1.1-fold (0.05 log units) below the measured one; low and high end bracket the measured number.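

Among the three compounds, only compound 3 gives a number rather than a limit in this assay, at 56000 nM. Going by these compounds alone, this gives the position on the oxygen its one readable step, an at least 6.2-fold lower number from compound 1 to compound 3 (0.79 log units; beyond the scatter), with 2,4,6-trichlorophenyl in place of 4-fluorophenyl. The exchange of 2,4,6-trimethylphenyl for 2,4,6-trichlorophenyl still cannot be read, and neither can the step from 4-fluorophenyl to 2,4,6-trimethylphenyl, since compound 2 gives only a limit: the limit of > 34000 nM in this assay, at which 1 of the 3 values shown sits.

The compounds shown leave open whether 2,4,6-trimethylphenyl and 2,4,6-trichlorophenyl differ at all in this assay, and how far the number for compound 1 lies from that of compound 3. They also leave open how this assay responds to an amine or a carboxylic acid on the phenyl ring, or to a longer alkyl chain on the oxygen in place of the ring.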